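A few compounds are considered here, and "the series" means these few. Any claim that something is new, unique, unknown or untested is made for them only; others in the source may bear on it.

Going by the values given here, compound 3 `COc1cccc(/C=N/NC(=O)CSc2nnnn2-c2cccc3ccccc23)c1OC` is the one compound of the three measured that returns an actual number in an ADME assay on MT4 cells (Homo sapiens) for cytotoxicity, read by MTT assay; a higher number here means that more compound is tolerated, a lower number that less compound is tolerated: compound 3 gives 192000 nM. Compound 1 `O=C(CSc1nnnn1-c1cccc2ccccc12)N/N=C/c1ccc(F)cc1` reaches a limit of this assay, and in this assay compound 1 gives > 307000 nM. Compound 2 `O=C(CSc1nnnn1-c1cccc2ccccc12)N/N=C/c1ccc([N+](=O)[O-])cc1` also reaches a limit of this assay, where compound 2 gives >= 260000 nM. The comparisons that lead to compound 3 are therefore read from limits only: an at least 1.5-fold lower number from compound 1 to compound 3 (0.20 log units; that floor lies within the scatter), and an at least 1.3-fold lower number from compound 2 to compound 3 (0.13 log units; that floor lies within the scatter). Between the two limit compounds, a step that the two limits leave unreadable from compound 1 to compound 2.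

Compound 4 `COc1cc(/C=N/NC(=O)CSc2nnnn2-c2cccc3ccccc23)ccc1O` carries a further change on the same side of the molecule: 4-hydroxy-3-methoxyphenyl in place of 2,3-dimethoxyphenyl on a carbon with a double bond to nitrogen. Among the compounds with values here, none of the measured steps moves from compound 3 to a hydroxy-bearing ring, so nothing speaks directly to this change. What is known is that changing the ring on the carbon with a double bond to nitrogen has not produced a step beyond the scatter, the floors of the steps from compound 1 and compound 2 to compound 3 both lying within it. In this assay compound 4 is therefore expected to stay close to compound 3, with a 1.0-fold higher number from compound 3 to compound 4 (0.02 log units; within the scatter). The estimate for compound 4 is 200000 nM, with a range from 100000 nM to 400000 nM.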

Compound 4, half-maximal cytotoxic concentration: > 287000 nM
Compound 4: no number, only a limit; the forecaster's own chance of this, stated with the estimate: 40%; at least 1.4-fold (0.15 log units) between middle value and limit.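

Going by these compounds alone, the ring on the carbon with a double bond to nitrogen now carries a hydroxy group: 4-hydroxy-3-methoxyphenyl has 1 hydrogen-bond donor where 2,3-dimethoxyphenyl has 0, and in this assay compound 4 reaches a limit and gives no number: the limit of > 287000 nM in this assay, at which 1 of the 4 values shown sits. The change reads as an at least 1.4-fold higher number from compound 3 to compound 4 (0.17 log units; that floor lies within the scatter), so this hydroxy-bearing ring does not bring a lower number than the one compound 3 gives, and compound 3 remains the only compound of the four with an actual number. The steps that link compound 4 with compound 1 and compound 2 cannot be read, as each has a limit at both ends, so the ring on this carbon cannot be ranked among these three compounds.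

The compounds shown leave open where the actual value of compound 4 lies, and whether the hydroxy group or the different arrangement of the methoxy group on the ring carries the step. They also do not tell how this assay would respond to an amine or a carboxylic acid on this ring.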